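A Methoxy Addition Weighed Against a Single Precedent

This account rests on a few compounds, and the source may have more. Where it says the series, first, only, none or still open, it means among the compounds named here.

Measured so far in a functional assay on HCT-116 cells (Homo sapiens) for cytotoxicity, read by MTT assay, with a stated time of 48 h; on this read-out lower numbers stand for stronger inhibition and higher numbers for weaker inhibition:
compound 1, `Nc1nc(-c2ccccc2)cn1/N=C/c1cc2ccccc2nc1Cl`, gives 6920 nM
compound 2, `Cc1ccc2nc(Cl)c(/C=N/n3cc(-c4ccccc4)nc3N)cc2c1`, gives 7120 nM

Going by the values given here, compound 2 holds the highest of the two numbers, but its only neighbour is compound 1, and the step of a 1.0-fold higher number from compound 1 to compound 2 (0.01 log units; within the scatter) lies within the scatter, so the two stand level. Among the compounds with values here, that step, a methyl in place of hydrogen on an aromatic carbon, is the sole precedent available.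

Compound 3, `COc1ccc(-c2cn(/N=C/c3cc4cc(C)ccc4nc3Cl)c(N)n2)cc1`, is not yet measured. It differs from compound 2 by methoxy in place of hydrogen on an aromatic carbon. Within the data shown here, no measured step touches this part of the structure; the one step known, from compound 1 to compound 2, changed a different ring and left the number essentially unmoved. Nothing therefore points in either direction. The expectation is that the step of a 1.0-fold lower number from compound 2 to compound 3 (0.01 log units; within the scatter) stays within the scatter. Compound 3 is accordingly estimated at 7000 nM in this assay, with a range from 3000 nM to 17000 nM that reflects the absence of any directly relevant precedent.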

Compound 3, half-maximal inhibitory concentration: > 50000 nM
Compound 3: only a limit was reported; the forecaster's own chance of this, stated with the estimate: 5%; middle value at least 7.1-fold (0.85 log units) from the limit.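

In this assay, the phenyl ring proves to be a place where a change can matter, which the earlier pair could not show, since its methyl change lay on a different ring and stayed within the scatter. Going from phenyl to 4-methoxyphenyl, an addition of only 2 heavy atoms on an aromatic carbon, para to a large group, gives an at least 7.0-fold higher number from compound 2 to compound 3 (0.84 log units; beyond the scatter), so even a small group here can carry the read-out well away from the level of the earlier compounds. For compound 3 the reported value is a limit and not a number, so the step gives only a minimum size: the limit of > 50000 nM in this assay, at which 1 of the 3 values shown sits.

The compounds shown leave open whether this loss belongs to methoxy itself or would follow any addition at this place on the phenyl ring, a question that a fluorine or a hydroxyl there could help to settle. They also leave open whether methoxy would have the same effect elsewhere on the phenyl ring, or on the core of compound 1, which lacks the methyl.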